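A few compounds are considered here, and "the series" means these few. Any claim that something is new, unique, unknown or untested is made for them only; others in the source may bear on it.

Compound 1 `O=S(=O)(/C=C/c1ccc(F)cc1)Cc1ccc(Nc2ncnc3ccccc23)cc1` is the reference point in a functional assay on UACC-62 cells (Homo sapiens) (a lower number here means a stronger inhibitor of growth, a higher number a weaker inhibitor of growth), where compound 1 gives 5000 nM. Compound 2 `O=S(=O)(/C=C/c1ccc(Cl)cc1)Cc1ccc(Nc2ncnc3ccccc23)cc1` carries the change (chloro in place of fluoro on an aromatic carbon), and in this assay compound 2 gives 13000 nM, which is a 2.6-fold higher number from compound 1 to compound 2 (0.41 log units; beyond the scatter). Compound 3 `O=S(=O)(/C=C/c1ccc(F)cc1F)Cc1ccc(Nc2ncnc3ccccc23)cc1` differs from compound 1 by fluoro in place of hydrogen on an aromatic carbon. In this assay compound 3 reaches only a limit, > 100000 nM, so no number is known for it; this is the limit of > 100000 nM in this assay, at which 1 of the 3 values shown sits. That limit still amounts to an at least 20-fold higher number from compound 1 to compound 3 (1.30 log units; beyond the scatter), and, measured from compound 2, to an at least 7.6-fold higher number from compound 2 to compound 3 (0.88 log units; beyond the scatter).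

Compound 4 `O=S(=O)(/C=C/c1ccc(F)cc1Cl)Cc1ccc(Nc2ncnc3ccccc23)cc1` has not been measured. It differs from compound 3 by chloro in place of fluoro on an aromatic carbon, the same kind of change as chloro in place of fluoro on an aromatic carbon, though the place is not the same: in compound 1 the exchange is para to a large group, whereas in compound 3 it is ortho to a large group and meta to a fluoro group. Since compound 3 already sits at the limit and the earlier step of a 2.6-fold higher number from compound 1 to compound 2 (0.41 log units; beyond the scatter) raised the number, compound 4 is expected to stay at or beyond that limit, a step that the limit leaves unreadable from compound 3 to compound 4 being estimated. The estimate for compound 4 is 150000 nM, expected between 50000 nM and 500000 nM.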

Compound 4, concentration for 50% growth inhibition: 100000 nM
The estimate for compound 4 lay 1.5-fold (0.18 log units) above the measured number; the range from low to high includes it.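

In this assay, compound 4 is a weaker inhibitor of growth than the two compounds with a single halogen on the phenyl ring, with a 20-fold higher number from compound 1 to compound 4 (1.30 log units; beyond the scatter), and a 7.7-fold higher number from compound 2 to compound 4 (0.89 log units; beyond the scatter). Compound 3 stands only at a limit, > 100000 nM, so the one thing the exchange shows on this second core is a number no higher from compound 3 to compound 4 (the limit leaves the size open): the limit of > 100000 nM in this assay, at which 1 of the 4 values shown sits. Whether chloro in place of fluoro carries over with the same size from the core of compound 1 to the core of compound 3 therefore remains unshown: the same change on two cores in this assay, a 2.6-fold higher number (0.41 log units; beyond the scatter) from compound 1 to compound 2 and a number no higher (the limit leaves the size open) from compound 3 to compound 4; the limit leaves it open whether they differ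

The compounds shown leave open where compound 3 truly lies, and so how the two steps would compare if both could be read. They also leave open how a methoxy group or an amine, in the place of the chloro of compound 4, would read in this assay.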